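The source may report more compounds than this note shows. Statements on the series, on what has been measured and on what is new or still open speak of the compounds shown alone.

Compound 1, `Cc1cc(NC(=O)Nc2cccc(Cl)c2)c2ccccc2n1`, gives 21000 nM.
Compound 2, `COC(=O)c1cccc(NC(=O)Nc2cc(C)nc3ccccc23)c1`, gives 26000 nM.
Compound 3, `Cc1cc(NC(=O)Nc2cccc([N+](=O)[O-])c2)c2ccccc2n1`, gives only a limit of the assay, > 25000 nM, and not a number.

All three values come from an ADME assay on HEK293 cells (Homo sapiens) for cytotoxicity, with a stated time of 72 h; on this read-out higher numbers stand for an effect only at larger amounts of compound and lower numbers for an effect already at smaller amounts. Of the two numbers, compound 1 has the lowest; its nearest neighbour is compound 2, and the step of a 1.2-fold higher number from compound 1 to compound 2 (0.09 log units; within the scatter). The remaining value is the limit of > 25000 nM in this assay, at which 1 of the 3 values shown sits. Towards compound 3 the step of an at least 1.1-fold higher number from compound 1 to compound 3 (0.07 log units; that floor lies within the scatter), while the step that the limit leaves unreadable from compound 2 to compound 3.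

The compound still to be measured is compound 4, `Cc1cc(NC(=O)Nc2ccccc2N)c2ccccc2n1`. Against compound 1 the change is 2-aminophenyl in place of 3-chlorophenyl on an amide-type nitrogen. The measured steps each swap a single group on that same ring and leave the rest of the molecule unchanged; the new change exchanges the whole ring. Neither measured step moved beyond the scatter, and the one limit sits in the same region as the two numbers, so no step beyond the scatter is expected in this assay for compound 4, in either direction, although a limit rather than a number may well come back.

Compound 4 is therefore expected near 25000 nM, with a range from 12000 nM to 50000 nM. That estimate means an expected step of a 1.2-fold higher number from compound 1 to compound 4 (0.08 log units; within the scatter).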

Compound 4, half-maximal effective concentration: > 25000 nM
Compound 4: a limit, no number; the forecaster's own chance of this, stated with the estimate: 40%; the middle value lies on the limit itself.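

In this assay the exchange of 3-chlorophenyl for 2-aminophenyl on the amide-type nitrogen gives an at least 1.1-fold higher number from compound 1 to compound 4 (0.07 log units; that floor lies within the scatter) and so leaves compound 4 with a limit rather than a number. Among these compounds, the earlier steps swapped only a single group on the ring, so this is the first look at what happens when the ring as a whole is replaced, and even then the readable floor of the step stays within the usual scatter. The true size of this step cannot be read, and the same goes for every other step that ends on a limit, because the read-out gives no number for these compounds: the limit of > 25000 nM in this assay, at which 2 of the 4 values shown sit.

The compounds shown leave open whether this result belongs to the amine itself or to the 2-aminophenyl ring as a whole, as no second ring carrying an amine stands beside it for comparison. Also open, on these data alone, is how a carboxylic acid or a longer chain on the ring would read in this assay and whether any change to this ring can give a step beyond the scatter.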